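Trading a pyrazole for an allyl group on the amide nitrogen

A few compounds are considered here, and "the series" means these few. Any claim that something is new, unique, unknown or untested is made for them only; others in the source may bear on it.

This account follows a set of aryloxyacetamides bearing a thiophen-2-ylmethyl group on the amide nitrogen, tested in an assay on HEK293 cells for agonist activity at transient receptor potential cation channel subfamily M member 8 (Homo sapiens), read by fluorescence and calcium flux, with a stated time of 15 min; a lower number here means that less compound is needed, a higher number that more compound is needed for the effect. Compound 1, `Cc1ccc(OCC(=O)N(Cc2cccs2)c2c[nH]nc2C)cc1`, carries a 3-methyl-1H-pyrazol-4-yl group on that nitrogen and gives 0.4 nM. Among the three measured compounds it holds the second highest number. Compound 2, `O=C(COc1ccc2c(c1)CCC2)N(Cc1cccs1)c1ccn[nH]1`, gives 0.001 nM, a far lower number than compound 1 shows, and the gap lies beyond the scatter. Compound 3, `CCN(Cc1cccs1)C(=O)COc1ccc(OC)cc1`, which carries an ethyl group on the amide nitrogen in place of the aromatic group, gives 120 nM, a far higher number than compound 1 shows, again beyond the scatter.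

Compound 4, `C=CCN(Cc1cccs1)C(=O)COc1ccc(C)cc1`, has not yet been measured. It differs from compound 1 in one place: allyl in place of 3-methyl-1H-pyrazol-4-yl on an amide-type nitrogen. Going by the values given here, no measured pair describes exactly this change, but compound 3, the only measured compound with a non-aromatic group on the amide nitrogen, gives 120 nM, and compound 4 is expected to behave more like it than like compound 1. For this reason a large step upward is expected, a 150-fold higher number from compound 1 to compound 4 (2.18 log units; beyond the scatter), beyond the scatter. Compound 4 is therefore estimated to give 60 nM, with a plausible range from 5 nM to 700 nM.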

Compound 4, half-maximal effective concentration: 20 nM
Compound 4: middle estimate off by 3.0-fold (0.48 log units), on the high side; the measured number falls inside the stated range.
By their numbers in this assay, from the lowest: compound 2; then compound 1; then compound 4; then compound 3.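

In this assay, going by these compounds alone, the exchange gives a 50-fold higher number from compound 1 to compound 4 (1.70 log units; beyond the scatter) and so provides the first step that isolates the group on the amide nitrogen, since the earlier compounds differ from one another in more than one place. With the rest of compound 1 held fixed, this position proves sensitive to the change, and allyl does not match the 3-methyl-1H-pyrazol-4-yl group here. The exchange removes the five-membered aromatic ring, its two nitrogens, and its hydrogen-bond donor and acceptor together. The single step cannot be divided among these features, and nothing shown gives a reason for it.

The compounds shown leave open which of those features carries the difference, and a phenyl group or a 2-aminoethyl chain on the same nitrogen would help to separate the ring from its nitrogens. Within the data shown here, they also leave open whether the step would keep its size with a different aryloxy part, such as the one carried by compound 2, whose pyrazole group also differs from that of compound 1.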